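Thiosemicarbazone series: thiophen-2-yl for phenyl on the hydrazone carbon

The source may hold more compounds than are shown below. What is called first, only, known or untested is meant among the compounds shown, and "the series" means these compounds.

Compound 1 `CC1=CC[C@H](C(C)(C)NC(=S)NN)CC1` carries the free hydrazinecarbothioamide. In a functional assay on K562 cells (Homo sapiens) for inhibition, read by sulforhodamine B assay, with a stated time of 48 h (on this read-out higher numbers stand for weaker inhibition of growth and lower numbers for stronger inhibition of growth), compound 1 gives only a limit, > 100000 nM (the limit of > 100000 nM in this assay, at which 1 of the 2 values shown sits). Compound 2 `CC1=CC[C@H](C(C)(C)NC(=S)N/N=C/c2ccccc2)CC1` bears the benzylidene hydrazone. In this assay, for the measured compounds named here, compound 2 gives 47600 nM, the only numerical value in the set. Compound 3 `CC1=CC[C@H](C(C)(C)NC(=S)N/N=C/c2cccs2)CC1` differs from compound 2 by thiophen-2-yl in place of phenyl on a carbon with a double bond to nitrogen. Going by the values given here, with no measured step of this kind, the change from compound 2 to compound 3 is expected to stay within the usual scatter, a 1.1-fold higher number from compound 2 to compound 3 (0.02 log units; within the scatter). For compound 3 the estimate in this assay is 50000 nM, within 15000 nM to 150000 nM.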

Compound 3, concentration for total growth inhibition: > 100000 nM
Compound 3: no number, only a limit (the forecaster's own chance of this, stated with the estimate: 30%); middle value at least 2.0-fold (0.30 log units) from the limit.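

On the carbon with a double bond to nitrogen, thiophen-2-yl in place of phenyl gives an at least 2.1-fold higher number from compound 2 to compound 3 (0.32 log units; beyond the scatter) in this assay. This position is therefore sensitive to the ring it carries, and the growth inhibition of compound 2 does not survive this exchange. Compound 3 gives only a limit, and the step between compound 1 and compound 3 cannot be read, since both are limits: the limit of > 100000 nM in this assay, at which 2 of the 3 values shown sit.

As far as these compounds go, whether a pyridin-2-yl ring or a phenyl carrying methoxy or chlorine on this carbon would lower the number stays open. For the compounds shown here, with compound 2 the only numerical value, no trend can be drawn.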